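Swapping a Difluorophenyl Ring for a Dichlorophenyl Ring

This account rests on a few compounds, and the source may have more. Where it says the series, first, only, none or still open, it means among the compounds named here.

Three compounds have been tested in a functional assay on BGC-823 cells (Homo sapiens) for antiproliferative activity, read by MTT assay, tested at 5 uM; a lower number here means a weaker effect, a higher number a stronger effect of the compound at the concentration tested:

compound 1 `COc1cc(C2=NN(C(C)=O)C(c3cccc(F)c3)O2)cc(OC)c1OC`: 37.7%
compound 2 `COc1cc(C(=O)N/N=C/c2ccccc2C(F)(F)F)cc(OC)c1OC`: 35.6%
compound 3 `COc1cc(C2=NN(C(C)=O)C(c3ccc(F)c(F)c3)O2)cc(OC)c1OC`: 21.6%

Compound 3 stands lowest of the three; its nearest neighbour is compound 2, and compound 1 lies furthest away, both beyond the scatter. Among the measured compounds shown here, the only single step among the measured compounds, a number 16.1 percentage points lower from compound 1 to compound 3 (beyond the scatter), put a second fluorine on the aromatic ring attached to the shared core and lowered the inhibition.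

Compound 4 `COc1cc(C2=NN(C(C)=O)C(c3c(Cl)cccc3Cl)O2)cc(OC)c1OC` differs from compound 3 in one place: 2,6-dichlorophenyl in place of 3,4-difluorophenyl on a saturated ring carbon. For the measured compounds named here, no measured step changes both the kind of halogen and its position on this ring at once, so the step from compound 1 to compound 3 bears on it only loosely, as a sign that altering the halogen pattern on this ring can shift the read-out by a modest amount. In this assay compound 4 is therefore expected to sit near compound 3, with a step of a number 4.4 percentage points higher from compound 3 to compound 4 (within the scatter) that may fall within the scatter. The estimate for compound 4 is 26%, with a range from 10% to 44%.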

Compound 4, a percentage reported as inhibition, at one concentration (the size of the read-out at that concentration, not a potency): 15.9%
The estimate for compound 4 lay 10.1 percentage points above the measured number; the range from low to high includes it.
By their numbers in this assay, from the lowest: compounds 4 and 3 (each within the scatter of the next); then compounds 2 and 1 (each within the scatter of the next).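

At this saturated ring carbon, in this assay, exchanging 3,4-difluorophenyl for 2,6-dichlorophenyl gives a step within the scatter (a number 5.7 percentage points lower from compound 3 to compound 4 (within the scatter)), so the two rings cannot be told apart here, even though both the halogen and its placement differ. Measured against the 3-fluorophenyl ring, the 2,6-dichlorophenyl ring gives a step beyond the scatter (a number 21.8 percentage points lower from compound 1 to compound 4 (beyond the scatter)), so among compounds 1, 3 and 4, both rings carrying two halogens read below the ring carrying one. Nothing available explains why these rings behave this way.

From the compounds shown here alone, because the halogen and its placement changed together, their separate contributions remain open. Also open, going by these compounds, is how a phenyl ring carrying an amine or a carboxylic acid at this position would behave.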